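Methyl removal on two cores: what compound 4 may give

A few compounds are considered here, and "the series" means these few. Any claim that something is new, unique, unknown or untested is made for them only; others in the source may bear on it.

Values in a functional assay on BXPC-3 cells (Homo sapiens) for inhibition, read by MTT assay, with a stated time of 72 h (a higher number here means a weaker inhibitor, a lower number a stronger inhibitor), so far:
- compound 1 `Cc1cnc(C(=O)Nc2ccc(Br)c3cccnc23)cn1`: > 10000 nM, a limit
- compound 2 `Cc1cnc(C(=O)Nc2cc(F)cc3cccnc23)cn1`: > 10000 nM, a limit
- compound 3 `O=C(Nc1ccc(Br)c2cccnc12)c1cnccn1`: 7500 nM

Compound 3 differs from compound 1 by one change, (hydrogen in place of methyl on an aromatic carbon). The step of an at least 1.3-fold lower number from compound 1 to compound 3 (0.12 log units; that floor lies within the scatter) is the only measured one for this change, and its floor is set by the limit of > 10000 nM in this assay, at which 2 of the 3 values shown sit. Compound 2 and compound 1 carry different cores; the difference between the two cores is not broken down here.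

Compound 4 `O=C(Nc1cc(F)cc2cccnc12)c1cnccn1` is not yet measured. It stands to compound 2 as compound 3 stands to compound 1: the same change, (hydrogen in place of methyl on an aromatic carbon), with the place described in identical words in both pairs.

For compound 4 the expected step is an at least 1.2-fold lower number from compound 2 to compound 4 (0.09 log units; that floor lies within the scatter), resting on the measured step of an at least 1.3-fold lower number from compound 1 to compound 3 (0.12 log units; that floor lies within the scatter) from compound 1 to compound 3, whose size is only a floor within the scatter. Compound 4 is therefore estimated at 8000 nM, between 3000 nM and 20000 nM, with a real chance that only a limit is reported again.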

Compound 4, half-maximal inhibitory concentration: > 10000 nM
Compound 4 was reported as a limit; the forecaster's own chance of this, stated with the estimate: 55%; middle value at least 1.2-fold (0.09 log units) from the limit.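

In this assay compound 4 gives > 10000 nM, a limit. Compound 2 gives > 10000 nM, also a limit, so no step can be read between compound 2 and compound 4: the limit of > 10000 nM in this assay, at which 3 of the 4 values shown sit.

The compounds shown leave open whether 5-methylpyrazin-2-yl to pyrazin-2-yl shifts the value beyond the scatter on either core.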